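The source may hold more compounds than are shown below. What is called first, only, known or untested is meant among the compounds shown, and "the series" means these compounds.

The measured compounds:

Compound 1, `CCc1nc(-c2ccc(OCCC(C)CCN3CCN(c4ccncc4)C3=O)cc2)no1`, gives in an ADME assay on cells (Homo sapiens) for cytotoxicity (a lower number here means that less compound is tolerated, a higher number that more compound is tolerated), a limit, > 25000 nM.
Compound 2, `O=C1N(Cc2ccccc2COc2ccc(-c3ccc(Cl)cc3)cc2)CCN1c1ccncc1`, gives in this assay a limit, > 1250 nM.
Compound 3, `CC(C)(CCCOc1ccc(-c2ccc(Cl)cc2)cc1)CN1CCN(c2ccncc2)C1=O`, gives in this assay 20000 nM.

Compound 1 therefore stands at a limit in this assay and not at a number: the value recorded for it is the limit of > 25000 nM in this assay, at which 1 of the 3 values shown sits. Compound 2 also sits at a limit, (the limit of > 1250 nM in this assay, at which 1 of the 3 values shown sits). Among the compounds with values here, compound 3 is the one compound of the three with a number rather than a limit, and its number lies near the limit of compound 1.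

Compound 4, `CC(CCOc1ccc(-c2nnn(C)n2)cc1)CCN1CCN(c2ccncc2)C1=O`, has not yet been measured in this assay. It differs from compound 1 in one place:

2-methyl-2H-tetrazol-5-yl in place of 5-ethyl-1,2,4-oxadiazol-3-yl on an aromatic carbon

Within the data shown here, no step between two measured compounds that differ in one place is known here, so nothing measured shows how this exchange shifts the read-out. The step from compound 1 to compound 4 in this assay is expected to be none beyond the usual scatter, a number no higher from compound 1 to compound 4 (the limit leaves the size open). Compound 4 is expected to give 25000 nM in this assay, with a range from 10000 nM to 60000 nM, and a limit rather than a number is the likelier outcome.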

Compound 4, half-maximal cytotoxic concentration: > 25000 nM
Compound 4 ended at the assay's limit (the forecaster's own chance of this, stated with the estimate: 65%); the middle value sits exactly at the limit.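

In this assay compound 1 and compound 4 sit at the same limit, so no step between them can be read: the limit of > 25000 nM in this assay, at which 2 of the 4 values shown sit.

The compounds shown leave open how far either lies past that limit, and whether exchanging 5-ethyl-1,2,4-oxadiazol-3-yl for 2-methyl-2H-tetrazol-5-yl shifts the read-out at all.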